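The compounds below may be only part of what the source reports. "The series", "measured", "known", "first", "only" and "open" are said of these compounds alone.

Working notes on the amide series. Compound 1 `O=C(Nc1ccc(Sc2nc3ccccc3s2)cc1)c1ccccc1` in an ADME assay on HEK293 cells (Homo sapiens) for cytotoxicity, read by reporter gene assay and resazurin assay, with a stated time of 48 h (a lower number here means that less compound is tolerated, a higher number that more compound is tolerated), gives > 100000 nM, which is a limit of the assay and not a number. Compound 2 `O=C(Nc1ccc(Sc2nc3ccccc3s2)cc1)c1ccccc1O` gives 74000 nM in this assay, and compound 3 `O=C(Nc1ccc(Sc2nc3ccccc3s2)c(Cl)c1)c1ccccc1O` gives 64000 nM. The change hydrogen in place of hydroxy on an aromatic carbon produces an at least 1.3-fold higher number from compound 2 to compound 1 (0.13 log units; that floor lies within the scatter), its upper side left open because of the limit of > 100000 nM in this assay, at which 1 of the 3 values shown sits. The cores of compound 2 and compound 3 differ by chloro in place of hydrogen on an aromatic carbon, which produces a 1.2-fold lower number from compound 2 to compound 3 (0.06 log units; within the scatter). Compound 4 `O=C(Nc1ccc(Sc2nc3ccccc3s2)c(Cl)c1)c1ccccc1` is not yet measured; it differs from compound 3 by hydrogen in place of hydroxy on an aromatic carbon, the same change as that made from compound 2 to compound 1, at the same kind of place. For compound 4 the step of a 1.4-fold higher number from compound 3 to compound 4 (0.15 log units; within the scatter) is expected in this assay, resting on the earlier step of an at least 1.3-fold higher number from compound 2 to compound 1 (0.13 log units; that floor lies within the scatter) and on compound 1 sitting at the limit of > 100000 nM in this assay, at which 1 of the 3 values shown sits. Compound 4 is estimated at 90000 nM, expected between 55000 nM and 150000 nM.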

Compound 4, half-maximal cytotoxic concentration: 90000 nM
Compound 4: middle estimate and measured number agree at the digits printed; low and high end bracket the measured number.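

In this assay, hydrogen in place of hydroxy gives a 1.4-fold higher number from compound 3 to compound 4 (0.15 log units; within the scatter), and set beside the earlier step this reads: the same change on two cores in this assay, an at least 1.3-fold higher number (0.13 log units; that floor lies within the scatter) from compound 2 to compound 1 and a 1.4-fold higher number (0.15 log units; within the scatter) from compound 3 to compound 4; the limit leaves it open whether they differ. Chloro in place of hydrogen gives an at least 1.1-fold lower number from compound 1 to compound 4 (0.04 log units; that floor lies within the scatter), and set beside its earlier step this reads: the same change on two cores in this assay, a 1.2-fold lower number (0.06 log units; within the scatter) from compound 2 to compound 3 and an at least 1.1-fold lower number (0.04 log units; that floor lies within the scatter) from compound 1 to compound 4; the limit leaves it open whether they differ. The two cores therefore show no disagreement for either change, but this does not show that either change has a real effect here, or that it carries from one core to another with a fixed size.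

As far as these compounds go, it remains open whether an amine or a carboxylic acid in place of the hydroxy would give a number beyond the scatter from that of compound 3 in this assay.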